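The compounds below may be only part of what the source reports. "The series", "measured", "known", "first", "only" and "open" are said of these compounds alone.

In a functional assay on LOX IMVI cells (Homo sapiens) for inhibition, read by sulforhodamine B assay, with a stated time of 48 h (a lower number here means a stronger inhibitor of growth, a higher number a weaker inhibitor of growth), compound 3, `COc1cc(C)cc(-c2nn(CC#N)cc2-c2ccnc(-c3ccc(N(C)C)cc3)c2)c1`, gives 14800 nM, the highest of the two numbers on record. Its nearest neighbour is compound 2, `Cc1cc(O)cc(-c2nn(CC#N)cc2-c2ccnc(-c3ccc(Oc4ccccc4)cc3)c2)c1`, which gives 3390 nM, a gap that lies beyond the scatter. Compound 1, `COc1cc(C)cc(-c2c(-c3ccnc(-c4ccc(C(C)=O)cc4)c3)cnn2CC#N)c1`, returns only a limit in this assay, > 100000 nM (the limit of > 100000 nM in this assay, at which 1 of the 3 values shown sits). Compound 4, `Cc1cc(O)cc(-c2nn(CC#N)cc2-c2ccnc(-c3ccc(N(C)C)cc3)c2)c1`, differs from compound 3 by hydrogen in place of methyl on an oxygen on an aromatic ring, so that 3-methoxy-5-methylphenyl becomes 3-hydroxy-5-methylphenyl. Within the data shown here, no step between two measured compounds shows this change on its own; compound 2, which carries the hydroxy group, also differs elsewhere. The step of a 1.9-fold lower number from compound 3 to compound 4 (0.27 log units; within the scatter) is expected to be a modest move toward a lower number. Compound 4 is estimated at 8000 nM, within 2000 nM to 30000 nM.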

Compound 4, concentration for total growth inhibition: 17800 nM
For compound 4 the middle estimate is 2.2-fold (0.35 log units) below the measured one, within the range that was stated.
By their numbers in this assay, from the lowest: compound 2; then compounds 3 and 4 (each within the scatter of the next). At a limit, above all of these: compound 1.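

In this assay, hydroxy and methoxy on this ring can't be told apart (a 1.2-fold higher number from compound 3 to compound 4 (0.08 log units; within the scatter)). With 3-hydroxy-5-methylphenyl held fixed, dimethylamino in place of phenoxy on an aromatic carbon does give a step beyond the scatter (a 5.3-fold higher number from compound 2 to compound 4 (0.72 log units; beyond the scatter)), so here the change at phenoxy moves the number and the change at methoxy does not. Nothing measured here accounts for either result. The compounds shown leave open whether an amine or an ethoxy group in place of hydroxy would read the same, and whether a carboxylic acid in place of phenoxy would keep the lower number.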